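Trifluoromethyl to Methoxy on the Aryl Ether of Compound 2

The compounds below may be only part of what the source reports. "The series", "measured", "known", "first", "only" and "open" are said of these compounds alone.

Of the compounds shown here, three have so far been measured in an assay on isolated protein for inhibition of sodium channel protein type 9 subunit alpha (Mus musculus), read by patch clamp; on this read-out higher numbers stand for weaker inhibition and lower numbers for stronger inhibition. Compound 2 `O=C1c2ccccc2CN1C1CCN(CC(O)COc2cccc(C(F)(F)F)c2)CC1` gives 790 nM in this assay. Compound 1 `O=C(c1ccccc1)c1ccccc1OCC(O)CN1CCC(C(=O)Nc2ccccc2)CC1` gives 1000 nM in this assay, a number that lies within the scatter of the number for compound 2, so the two cannot be told apart on this read-out. Compound 3 `O=C(c1ccccc1)c1ccccc1OCC(O)CN1CCN(c2cccc3[nH]c(=O)oc23)CC1` gives 31000 nM in this assay, a gap from compound 2 that is well beyond the scatter. Compound 2 thus has the lowest of the three numbers, though its gap to compound 1 is within the scatter.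

Compound 4 `COc1cccc(OCC(O)CN2CCC(N3Cc4ccccc4C3=O)CC2)c1` has not yet been measured. It differs from compound 2 in one place: methoxy in place of trifluoromethyl on an aromatic carbon. Within the data shown here, no pair of measured compounds shows this same change, so these data give no direct measure of how large a step it brings. The remainder of the molecule is kept exactly as in compound 2, and the expectation is a small step rather than a large one, if anything toward a higher number. The step from compound 2 to compound 4 is expected to be a 1.9-fold higher number from compound 2 to compound 4 (0.28 log units; within the scatter). Compound 4 is expected to give about 1500 nM in this assay, with a range from 500 nM to 5000 nM.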

Compound 4, half-maximal inhibitory concentration: 910 nM
Estimate against measurement, compound 4: 1.6-fold (0.22 log units) above; the measured number falls inside the stated range.
By their numbers in this assay, from the lowest: compounds 2, 4 and 1 (each within the scatter of the next); then compound 3.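

Among these compounds, this is the first step between two compounds that differ in only one place, and it isolates a single aromatic carbon: in this assay the change from 3-(trifluoromethyl)phenyl to 3-methoxyphenyl gives a 1.2-fold higher number from compound 2 to compound 4 (0.06 log units; within the scatter). Compound 2 and compound 4 therefore cannot be told apart on this read-out, so at this position the trifluoromethyl group is not needed to keep the number in this range, and methoxy, with fewer heavy atoms and one hydrogen-bond acceptor where trifluoromethyl has none, serves as well. No measurement is available that would explain why the two groups give such similar numbers.

Among the compounds shown here, a single step on one core shows only that these two groups can be exchanged here, and it does not show how widely this position accepts other groups. The compounds shown leave open whether a carboxylic acid, an amine or a longer chain such as ethoxy on this aromatic carbon would stay within the scatter of compound 2 or move the number clearly in either direction.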